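The compounds below may be only part of what the source reports. "The series", "measured", "known", "first", "only" and "open" are said of these compounds alone.

Working notes on a small urea series. All three measured members have been run through an ADME assay on the whole organism with Oryza sativa as the target, tested at 0.1 uM; on this read-out lower numbers stand for a stronger effect and higher numbers for a weaker effect at the one concentration tested. Compound 1 `CCOC(=O)c1cccc(NC(=O)N[C@H](C)c2ccccc2)c1` gives 99%. Compound 2 `CCOC(=O)c1ccc(NC(=O)N[C@H](C)c2ccccc2)cc1` gives 101%. Compound 3 `CC(=O)c1cccc(NC(=O)N[C@H](C)c2ccccc2)c1` gives 98%. Compound 2 stands highest of the three numbers, but its gaps to compound 1 and to compound 3 are both within the scatter, so no order among them is claimed. Compound 1 and compound 2 share the same atoms joined differently; the difference between the two cores is not broken down here.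

One structural change recurs. From compound 1 to compound 3 it is methyl in place of ethoxy on a carbonyl carbon and it made a number 1 percentage points lower from compound 1 to compound 3 (within the scatter). The same change, (methyl in place of ethoxy on a carbonyl carbon), with an identical place description, leads from compound 2 to the unmeasured compound 4 `CC(=O)c1ccc(NC(=O)N[C@H](C)c2ccccc2)cc1`. Because a number 1 percentage points lower from compound 1 to compound 3 (within the scatter) was seen, the step from compound 2 to compound 4 is expected to be a number 1 percentage points lower from compound 2 to compound 4 (within the scatter). Compound 4 is accordingly estimated at 100%, with a range from 92% to 107%.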

Compound 4, a percentage reported as activity, at one concentration (the size of the read-out at that concentration, not a potency): 96%
Compound 4: middle estimate off by 4 percentage points, on the high side; low and high end bracket the measured number.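

In this assay, methyl in place of ethoxy on a carbonyl carbon gives a number 5 percentage points lower from compound 2 to compound 4 (within the scatter). Set beside the earlier step, the change reads alike on the two cores: the same change on two cores in this assay, a number 1 percentage points lower (within the scatter) from compound 1 to compound 3 and a number 5 percentage points lower (within the scatter) from compound 2 to compound 4, 4 percentage points apart, within the scatter of two such steps. This shows no detectable difference in how the change behaves on these two cores, but with both steps within the scatter, it does not show that the change has a real effect that carries from one core to the other.

On these data alone, whether any group on this part of the molecule can shift the read-out remains open. A carboxylic acid or an amine in place of the ethoxycarbonyl or acetyl group would test this, as would a longer chain in place of the methyl on the urea side.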